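Replacing the 4-Cyanophenyl Group with Cyclohexyl

The source may hold more compounds than are shown below. What is called first, only, known or untested is meant among the compounds shown, and "the series" means these compounds.

Compound 3 `CC[C@H](C)[C@H](N)CN(C(=O)[C@@H]1C[C@H]1c1ccc(C#N)cc1)c1ccc(-c2ccccc2)cc1` is one of three measured analogues built on a shared core. In a functional assay for agonist activity at G protein-coupled receptor 88 (Homo sapiens), read by HTRF and cAMP accumulation (a higher number here means that more compound is needed for the effect, a lower number that less compound is needed), compound 3 gives only a limit, > 25000 nM. Compound 1 `CC[C@H](C)[C@H](N)CN(C(=O)[C@@H]1C[C@H]1c1ccc(OC)cc1)c1ccc(-c2ccccc2)cc1` likewise gives only a limit in this assay, > 25000 nM. Compound 2 `CC[C@H](C)[C@H](N)CN(C(=O)[C@@H]1C[C@H]1c1cccc(F)c1)c1ccc(-c2ccccc2)cc1` gives a readable value in this assay, 560 nM. The measured steps are an at least 44-fold lower number from compound 1 to compound 2 (1.64 log units; beyond the scatter) and an at least 44-fold higher number from compound 2 to compound 3 (1.64 log units; beyond the scatter), while the step that the two limits leave unreadable from compound 1 to compound 3 cannot be sized since (the limit of > 25000 nM in this assay, at which 2 of the 3 values shown sit). Compound 4 `CC[C@H](C)[C@H](N)CN(C(=O)[C@@H]1C[C@H]1C1CCCCC1)c1ccc(-c2ccccc2)cc1` differs from compound 3 by cyclohexyl in place of 4-cyanophenyl on a saturated ring carbon. Going by the values given here, no measured step exchanges the aromatic ring for a non-aromatic one, so this change is untested; what the two large steps show is that the group on the saturated ring carbon alone carries the number from the limit to a readable value and back. Compound 4 is therefore expected to fall somewhere between these outcomes, with an at least 3.1-fold lower number from compound 3 to compound 4 (0.49 log units; beyond the scatter) estimated. In this assay compound 4 is expected to give about 8000 nM, estimated within 1500 nM to 25000 nM.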

Compound 4, half-maximal effective concentration: > 25000 nM
Compound 4: no number, only a limit; the forecaster's own chance of this, stated with the estimate: 40%; middle value at least 3.1-fold (0.49 log units) away from the limit.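

In this assay compound 4 gives only a limit, > 25000 nM. Cyclohexyl in place of the aromatic ring does not bring a readable value, and the change from 3-fluorophenyl to cyclohexyl gives an at least 44-fold higher number from compound 2 to compound 4 (1.64 log units; beyond the scatter). Of the four groups tried on this saturated ring carbon, only the 3-fluorophenyl of compound 2 gives a readable value, while the steps among compound 1, compound 3 and compound 4 cannot be read: the limit of > 25000 nM in this assay, at which 3 of the 4 values shown sit.

The compounds shown leave open whether the readable value needs the fluorine at all, as unsubstituted phenyl would show, or tolerates another group in its place, such as 3-chlorophenyl. They also leave open whether 4-fluorophenyl would give a readable value.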